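This account rests on a few compounds, and the source may have more. Where it says the series, first, only, none or still open, it means among the compounds named here.

Measured so far, both in a functional assay on NCI-H1299 cells (Homo sapiens) for inhibition, read by CCK-8 assay, with a stated time of 72 h, tested at 10 uM; on this read-out lower numbers stand for a weaker effect and higher numbers for a stronger effect at the one concentration tested:

Compound 1 `CN(C)C(=O)c1cc2cnc(Nc3ccc(S(=O)(=O)NCCCN=C=S)cc3)nc2n1C1CCCC1` gives 72.8%
Compound 2 `CN(C)C(=O)c1cc2cnc(Nc3ccc(S(=O)(=O)NCCCCN=C=S)cc3)nc2n1C1CCCC1` gives 72.7%

Compound 2 stands at the lowest of these two numbers, yet compound 1 lies within the scatter of it, so the two are effectively alike. Compound 3 `CN(C)C(=O)c1cc2cnc(Nc3ccc(S(=O)(=O)NCCCCCN=C=S)cc3)nc2n1C1CCCC1` differs from compound 2 by a group of 4 heavy atoms (2 carbon, 1 nitrogen, 1 sulfur; no ring) in place of a group of 3 heavy atoms (1 carbon, 1 nitrogen, 1 sulfur; no ring), on a saturated chain carbon, four bonds along the chain from a sulfonamide nitrogen. Among the measured compounds shown here, the one measured step of the same kind, one bond nearer the sulfonamide nitrogen, was a number 0.1 percentage points lower from compound 1 to compound 2 (within the scatter), so no step beyond the scatter is expected here in this assay. Compound 3 is therefore estimated at 72.5%, between 62% and 81%. The expected step is a number 0.2 percentage points lower from compound 2 to compound 3 (within the scatter).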

Compound 3, a percentage reported as inhibition, at one concentration (the size of the read-out at that concentration, not a potency): 83.4%
Estimate against measurement, compound 3: 10.9 percentage points below; measured number outside the range, above it.
By their numbers in this assay, from the lowest: compounds 2 and 1 (each within the scatter of the next); then compound 3.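

In this assay, this place on the saturated chain, four bonds along the chain from a sulfonamide nitrogen, does respond to the longer group, bringing a number 10.7 percentage points higher from compound 2 to compound 3 (beyond the scatter) and, across the whole series, a number 10.6 percentage points higher from compound 1 to compound 3 (beyond the scatter) as well. The same kind of change one bond nearer the sulfonamide nitrogen gave no step beyond the scatter, so these three compounds show no steady rise with length, and compound 1 and compound 2 go against one. No available measurement accounts for this jump.

Going by these compounds, whether a longer chain would raise the number further, hold it or lower it remains open. So does the effect of an amine at the end of the chain.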